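The compounds below may be only part of what the source reports. "The series", "measured", "known", "first", "only" and "open" are said of these compounds alone.

Measured in a functional assay on A549/CDDP cells (Homo sapiens) for antiproliferative activity, read by MTT assay, with a stated time of 72 h; a higher number here means a weaker inhibitor, a lower number a stronger inhibitor:
Compound 1 `Cc1nc(C)c(/C=C/C(=O)/C=C/c2ccc(F)cc2)nc1C`: 7440 nM
Compound 2 `Cc1nc(C)c(/C=C/C(=O)/C=C/c2ccc(C(F)(F)F)cc2)nc1C`: 6900 nM

In this assay, compound 2 gives 6900 nM, which lies within the scatter of compound 1, so the two cannot be ranked. Compound 3 `Cc1ccc(/C=C/C(=O)/C=C/c2nc(C)c(C)nc2C)cc1` is the next structure to consider, and it differs from compound 2 as follows: methyl in place of trifluoromethyl on an aromatic carbon. This is methyl in place of trifluoromethyl on an aromatic carbon, para to a large group. For the measured compounds named here, only one measured step bears on this change: a 1.1-fold lower number from compound 1 to compound 2 (0.03 log units; within the scatter), with trifluoromethyl in place of fluoro on an aromatic carbon. Going by the values given here, that step stayed within the scatter, but it is a single step, and no methyl compound has yet been measured. A shift beyond the scatter in this assay is therefore not expected. The expected change is a 1.0-fold higher number from compound 2 to compound 3 (0.01 log units; within the scatter). Compound 3 is expected to give 7000 nM, with an estimated range from 3500 nM to 14000 nM.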

Compound 3, half-maximal inhibitory concentration: 3990 nM
Estimate against measurement, compound 3: 1.8-fold (0.24 log units) above; the measured number falls inside the stated range.
By their numbers in this assay, from the lowest: compounds 3, 2 and 1 (each within the scatter of the next).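

At this aromatic carbon, para to a large group, methyl now stands alongside fluoro and trifluoromethyl, giving the first group there without fluorine, and in this assay its exchange for trifluoromethyl gives a 1.7-fold lower number from compound 2 to compound 3 (0.24 log units; within the scatter) as the result. Its exchange for fluoro gives a 1.9-fold lower number from compound 1 to compound 3 (0.27 log units; within the scatter) as the matching result, so these two steps are larger than the earlier one, yet the three groups still cannot be ranked. No measurement shown accounts for these numbers.

The compounds shown leave open whether a different kind of group on this carbon, such as an amine, a carboxylic acid or a longer chain, would move the number beyond the scatter. They also leave open whether any of these three groups would behave the same way on another part of the shared core.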